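This account rests on a few compounds, and the source may have more. Where it says the series, first, only, none or still open, it means among the compounds named here.

Values in a functional assay on DU-145 cells (Homo sapiens) for inhibition, read by trypan blue exclusion, with a stated time of 96 h; on this read-out higher numbers stand for weaker inhibition of growth and lower numbers for stronger inhibition of growth:

Compound 1 `O=C(O)c1ccc(C(=O)/C(=C\c2ccc(Br)cc2)SCc2ccc(F)cc2)cc1` — > 100000 nM, a limit of the assay (the limit of > 100000 nM in this assay, at which 1 of the 3 values shown sits).
Compound 2 `O=C(/C(=C\c1ccc(Cl)c([N+](=O)[O-])c1)S(=O)(=O)c1ccc(Br)cc1)c1ccc(Br)cc1` — 10000 nM.
Compound 3 `O=C(O)c1ccc(C(=O)/C(=C\c2ccc(Cl)c([N+](=O)[O-])c2)SCc2ccc(F)cc2)cc1` — 1000 nM.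

Compound 4 `O=C(/C(=C\c1ccc(Br)cc1)S(=O)(=O)c1ccc(Br)cc1)c1ccc(Br)cc1` is not yet measured. The difference between the cores of compound 2 and compound 3 is not broken down here. Within the data shown here, the one change that is counted twice is 4-bromophenyl in place of 4-chloro-3-nitrophenyl on a double-bonded chain carbon bound to a double-bonded chain carbon; between measured compounds it gave an at least 100-fold higher number from compound 3 to compound 1 (2.00 log units; beyond the scatter), with the value of compound 1 sitting at a limit rather than a number. The same change is made from compound 2 to compound 4: 4-bromophenyl in place of 4-chloro-3-nitrophenyl on a double-bonded chain carbon bound to a double-bonded chain carbon, at the same place. Compound 4 is therefore expected to show a 20-fold higher number from compound 2 to compound 4 (1.30 log units; beyond the scatter) in this assay, resting on the step from compound 3 to compound 1 an at least 100-fold higher number from compound 3 to compound 1 (2.00 log units; beyond the scatter) and on the value of compound 2 10000 nM. For compound 4 the estimate is 200000 nM, likely reported as a limit, within 50000 nM to 1000000 nM.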

Compound 4, concentration for 50% growth inhibition: 10000 nM
For compound 4 the middle estimate is 20-fold (1.30 log units) above the measured one, outside the stated range (below it).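

In this assay, 4-bromophenyl in place of 4-chloro-3-nitrophenyl on the core of compound 2 gives no change at the digits printed from compound 2 to compound 4 (within the scatter), so the step seen on the core of compound 3 does not carry over to this core: the same change on two cores in this assay, an at least 100-fold higher number (2.00 log units; beyond the scatter) from compound 3 to compound 1 and no change at the digits printed (within the scatter) from compound 2 to compound 4, at least 100-fold (2.00 log units) apart, beyond the scatter of two such steps

Compound 1 sits at a limit of the assay, so the earlier step has no known upper size: the limit of > 100000 nM in this assay, at which 1 of the 4 values shown sits.

These two pairs do not show which part of the cores governs the difference, and they say nothing about other cores.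

Open, from the compounds shown here alone, is how the same change behaves on a core with an amine in place of the carboxylic acid of compound 3. Also open, going by these compounds, is whether the chlorine or the nitro group of 4-chloro-3-nitrophenyl carries the step on that core.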